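Trifluoromethyl for chloro on the terminal aryl ring

The compounds below may be only part of what the source reports. "The series", "measured", "known", "first", "only" and "open" are said of these compounds alone.

Measured compounds:
Compound 1 `COc1cc(-c2nn(-c3cccc(NC(=O)Nc4ccc(Cl)c(Cl)c4)c3)cc2-c2ccncc2)ccc1Cl`: 1470 nM
Compound 2 `O=C(Nc1cccc(-n2cc(-c3ccncc3)c(-c3ccc(Cl)c(O)c3)n2)c1)Nc1ccc(Cl)c(Cl)c1`: 1310 nM
Compound 3 `O=C(Nc1cccc(-n2cc(-c3ccncc3)c(-c3ccc(Cl)c(O)c3)n2)c1)Nc1cc(C(F)(F)F)cc(C(F)(F)F)c1`: 1030 nM

In a functional assay on SN12C cells (Homo sapiens) for inhibition, read by sulforhodamine B assay, with a stated time of 48 h (on this read-out higher numbers stand for weaker inhibition of growth and lower numbers for stronger inhibition of growth), compound 2 gives 1310 nM, second highest of the three numbers, within the scatter of both compound 1 and compound 3. Compound 4 `O=C(Nc1cccc(-n2cc(-c3ccncc3)c(-c3ccc(Cl)c(O)c3)n2)c1)Nc1ccc(Cl)c(C(F)(F)F)c1` differs from compound 2 by trifluoromethyl in place of chloro on an aromatic carbon. Among the measured compounds shown here, the one measured single step, a 1.1-fold lower number from compound 1 to compound 2 (0.05 log units; within the scatter), concerns a different place and carries no information on this change. Compounds 2 and 3 differ on the same ring, and their values lie within the scatter of each other. No step beyond the scatter is therefore expected in this assay, in either direction. Compound 4 is estimated at 1100 nM, range 500 nM to 2500 nM, a step of a 1.2-fold lower number from compound 2 to compound 4 (0.08 log units; within the scatter) from compound 2 that is expected to stay within the scatter.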

Compound 4, concentration for 50% growth inhibition: 1120 nM
Compound 4: middle estimate off by 1.0-fold (0.01 log units), on the low side, within the range that was stated.
By their numbers in this assay, from the lowest: compounds 3, 4, 2 and 1 (each within the scatter of the next).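

In this assay, trifluoromethyl in place of chloro on this aromatic carbon, ortho to a chloro group, gives a 1.2-fold lower number from compound 2 to compound 4 (0.07 log units; within the scatter) and so stays within the scatter. Among the compounds shown here, the only earlier single step concerned a different place, so this is the first direct reading here: going from 1 heavy atom to 4 at this carbon leaves the growth-inhibition number effectively unchanged. No measurement is available to explain this result.
Open, as far as these compounds go, is whether an amine or a carboxylic acid on this carbon would also stay within the scatter. Also open, from the compounds shown here alone, is whether the same change would behave alike with the methoxy group of compound 1 in place of the hydroxy group of compound 4.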